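The source may report more compounds than this note shows. Statements on the series, on what has been measured and on what is new or still open speak of the compounds shown alone.

Working notes on the series, read in a physicochemical assay for solubility, in phosphate buffer, with a stated time of 2 h, at pH 7.4; a lower number here means a less soluble compound, a higher number a more soluble compound. Compound 1 `COc1ccc(-c2csc(Nc3ccc(Cl)cn3)n2)nc1` gives < 10000 nM, which is a limit and not a number. Compound 2 `Clc1ccc(Nc2nc(-c3ccccn3)c(Cl)s2)nc1` gives < 10000 nM, also a limit. Compound 2 therefore stands at the limit of < 10000 nM in this assay, at which 2 of the 2 values shown sit. Compound 3 `COc1ccc(-c2nc(Nc3ccc(Cl)cn3)sc2Cl)nc1` differs from compound 2 by one change: methoxy in place of hydrogen on an aromatic carbon. Within the data shown here, no measured step is available to size this change, so no shift beyond the scatter is expected in this assay. The expected step is a step that the limit leaves unreadable from compound 2 to compound 3. For compound 3 the estimated value is 5000 nM, with an estimated range of 1000 nM to 10000 nM.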

Compound 3, solubility: < 10000 nM
Compound 3 was reported as a limit (the forecaster's own chance of this, stated with the estimate: 75%); the middle value does not contradict the limit.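

No step can be read among compound 1, compound 2 and compound 3 in this assay because all three values are limits: the limit of < 10000 nM in this assay, at which 3 of the 3 values shown sit.
The compounds shown leave open where the actual solubility of each lies, and so what either single change does.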